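Removing the hydroxy from compound 3: expected cytotoxicity of compound 4

A few compounds are considered here, and "the series" means these few. Any claim that something is new, unique, unknown or untested is made for them only; others in the source may bear on it.

This account concerns three measured biphenyl-type compounds and one that is not yet measured. Compound 1 `COc1cc(OC)cc(-c2ccccc2O)c1`, compound 2 `COc1cc(O)cc(-c2ccccc2)c1` and compound 3 `COc1cc(-c2ccccc2)cc(OC)c1O` were all tested in a functional assay on A549 cells (Homo sapiens) for cytotoxicity, read by sulforhodamine B assay; on this read-out lower numbers stand for stronger inhibition and higher numbers for weaker inhibition. Compound 1 returned only a limit of the assay, > 10000 nM. Compound 2 likewise returned only a limit, > 10000 nM. Compound 3 also returned only a limit, > 10000 nM. Compound 3 therefore stands where the other two stand: the limit of > 10000 nM in this assay, at which 3 of the 3 values shown sit, and no number distinguishes any of them from the others.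

Compound 4 `COc1cc(OC)cc(-c2ccccc2)c1` differs from compound 3 in one place: hydrogen in place of hydroxy on an aromatic carbon.

Going by the values given here, since no measured pair here differs in a single place, no measured step can guide the size of this change. With every shown value sitting at the limit, the expected step is none beyond the scatter, and the expectation is that compound 4 also reports only a limit in this assay, so the estimated step that the limit leaves unreadable from compound 3 to compound 4 carries little weight. The estimated value for compound 4 is 20000 nM, ranging from 8000 nM to 60000 nM.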

Compound 4, half-maximal inhibitory concentration: > 10000 nM
Compound 4: only a limit was reported; the forecaster's own chance of this, stated with the estimate: 85%; the middle value is on the limit's open side.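

Compound 4 sits at a limit of the assay, as do compound 1, compound 2 and compound 3, so none of the steps to compound 4 can be read in this assay: the limit of > 10000 nM in this assay, at which 4 of the 4 values shown sit.

The compounds shown leave open whether any of them truly differs from another in this assay, and what a hydroxy or methoxy group changes there.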